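Oxolanyl in place of methyl on the pyrazole nitrogen

The compounds below may be only part of what the source reports. "The series", "measured", "known", "first", "only" and "open" are said of these compounds alone.

Compound 1 `Cc1c(Nc2nc(N)c3c(C#N)c(N4CCC[C@H]4C)n(C)c3n2)cnn1C` stands with the highest number of the two measured in an assay on isolated protein for inhibition of Leucine-rich repeat serine/threonine-protein kinase 2 variant G2019S (Homo sapiens), read by TR-FRET and LanthaScreen, with stated times of 50 min and 30 min, in the presence of a further agent that is not named here; on this read-out lower numbers stand for stronger inhibition and higher numbers for weaker inhibition: compound 1 gives 43 nM. Compound 2 `C[C@@H]1CCCN1c1c(C#N)c2c(N)nc(Nc3cn[nH]c3)nc2n1C` gives 6 nM. Among the compounds with values here, the one measured step, a 7.2-fold lower number from compound 1 to compound 2 (0.86 log units; beyond the scatter), puts 1H-pyrazol-4-yl in place of 1,5-dimethyl-1H-pyrazol-4-yl on a nitrogen on an aromatic ring. Compound 3 `Cc1c(Nc2nc(N)c3c(C#N)c(N4CCC[C@H]4C)n(C)c3n2)cnn1[C@H]1CCOC1` changes only the group on the aromatic nitrogen: oxolan-3-yl in place of methyl on an aromatic nitrogen. Within the data shown here, no measured step alters this position alone; the step from compound 1 to compound 2 is the only one that touches the same ring, and it removed the methyl groups rather than enlarging one, so it gives little guidance for compound 3. A step of no more than the scatter is therefore expected in this assay, with the direction open; the expected step is a 1.2-fold lower number from compound 1 to compound 3 (0.09 log units; within the scatter). Compound 3 is expected to give 35 nM, within 12 nM to 100 nM.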

Compound 3, half-maximal inhibitory concentration: 14 nM
For compound 3 the middle estimate is 2.5-fold (0.40 log units) above the measured one, and the stated range covers the measured number.
By their numbers in this assay, from the lowest: compound 2; then compound 3; then compound 1.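

In this assay, oxolan-3-yl in place of methyl on the aromatic nitrogen gives a 3.1-fold lower number from compound 1 to compound 3 (0.49 log units; beyond the scatter), so this nitrogen carries a larger group, with a five-membered non-aromatic ring and a hydrogen-bond acceptor, without loss of inhibition. The earlier step removed both methyl groups together, whereas this change alters the group on the nitrogen alone and keeps the methyl on the neighbouring ring atom named in the structure comparison. No supporting evidence bears on why the number falls.

The compounds shown do not separate the contribution of the ring carbons from that of the ring oxygen, which a cyclopentyl group on the same nitrogen would address. Going by these compounds, the opposite stereocentre of the oxolan-3-yl group, and a basic amine such as a piperidin-4-yl group at this position, also remain open.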